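Series notes: ester terminus changes and microsomal half-life

The compounds below may be only part of what the source reports. "The series", "measured", "known", "first", "only" and "open" are said of these compounds alone.

Compound 1 `CCOc1cc(NC(=O)C2(NC(=O)c3ccc4c(C5CCCC5)c(-c5ncc(Cl)cn5)n(C)c4c3)CCC2)ccc1/C=C/C(=O)OC(=O)C[C@H](O)C(=O)O` and compound 2 `CCOc1cc(NC(=O)C2(NC(=O)c3ccc4c(C5CCCC5)c(-c5ncc(Cl)cn5)n(C)c4c3)CCC2)ccc1/C=C/C(=O)OCC(=O)OCc1ccc(Cl)cc1` share one core and differ only in the group carried on an oxygen next to a carbonyl group. In an ADME assay (liver) for pharmacokinetics, with Liver microsome (Homo sapiens) as the target, using microsomes (on this read-out higher numbers stand for a longer-lived compound and lower numbers for a shorter-lived compound), compound 1 gives 5.57 h. In this assay compound 2 gives 5.62 h. The step between them reads a 1.0-fold higher number from compound 1 to compound 2 (0.00 log units; within the scatter), so compound 2 stands level with compound 1: the two numbers lie within the scatter of each other and no order between them can be read.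

Compound 3 `CCOc1cc(NC(=O)C2(NC(=O)c3ccc4c(C5CCCC5)c(-c5ncc(Cl)cn5)n(C)c4c3)CCC2)ccc1/C=C/C(=O)OCC(N)=O` is not yet measured. It differs from compound 2 in this way: amino in place of (4-chlorobenzyl)oxy on a carbonyl carbon. Going by the values given here, the only measured step that bears on this change is the one at the same terminus, a 1.0-fold higher number from compound 1 to compound 2 (0.00 log units; within the scatter), which left the half-life unchanged although a large group was exchanged there. On that basis the step to compound 3 is expected to be a 1.0-fold lower number from compound 2 to compound 3 (0.00 log units; within the scatter), in no direction beyond the scatter. Compound 3 is therefore estimated to give 5.6 h in this assay, with a range from 2.8 h to 11 h.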

Compound 3, half-life: 0.983 h
Compound 3: middle estimate off by 5.7-fold (0.76 log units), on the high side; measured number outside the range, below it.
By their numbers in this assay, from the lowest: compound 3; then compounds 1 and 2 (each within the scatter of the next).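

In this assay, the group on a carbonyl carbon at this terminus is shown to matter: amino in place of (4-chlorobenzyl)oxy gives a 5.7-fold lower number from compound 2 to compound 3 (0.76 log units; beyond the scatter), the first step here that lies beyond the scatter. Cut at the oxygen next to a carbonyl group, carbamoylmethyl in place of (2-carboxy-2-hydroxyethyl)carbonyl gives a 5.7-fold lower number from compound 1 to compound 3 (0.75 log units; beyond the scatter), so two quite different groups that stood level with each other both separate from carbamoylmethyl, and the earlier level pair no longer reads as a position indifferent to what it carries. No measurement at hand accounts for this shorter half-life.

The compounds shown leave open whether the shift follows the entry of amino or the departure of (4-chlorobenzyl)oxy with its six-membered aromatic ring, as the single step changes both at once. Methoxy, hydroxy or methylamino on the same carbonyl carbon, or benzylamino carrying the same 4-chlorophenyl ring, would pull these two apart and show whether compound 3 marks a trend or stands alone.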